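This account rests on a few compounds, and the source may have more. Where it says the series, first, only, none or still open, it means among the compounds named here.

Measured so far in an ADME assay on MDCK cells (Canis lupus familiaris) for inhibition, read by LC-MS, with a stated time of 60 min, tested at 3 uM, in the presence of a further agent that is not named here; a lower number here means that the compound crosses the layer more slowly, a higher number that the compound crosses the layer faster:
- compound 2 `C[C@@H](N[C@H]1CCN(c2ccc(S(=O)(=O)NC(=O)CCC(=O)O)cc2)C1)c1cccc2ccccc12`: 5 nm/s
- compound 3 `C[C@@H](N[C@H]1CCN(c2ccc(C(=O)NCCS(=O)(=O)O)cc2)C1)c1cccc2ccccc12`: 4 nm/s
- compound 1 `C[C@@H](N[C@H]1CCN(c2ccc(S(=O)(=O)NC(=O)CC(=O)O)cc2)C1)c1cccc2ccccc12`: "not determined" (no result reported)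

Compound 1 therefore stands nowhere on the numbers shown; it carries no value in this assay. Compound 4 `C[C@@H](N[C@H]1CCN(c2ccc(C(=O)N[C@H](CCCCN)C(=O)O)cc2)C1)c1cccc2ccccc12` differs from it as follows: (5-amino-1-carboxypentyl)carbamoyl in place of ((carboxymethyl)carbonyl)sulfamoyl on an aromatic carbon. Among the compounds with values here, the only measured step, a 1.3-fold lower number from compound 2 to compound 3 (0.10 log units; within the scatter), likewise replaces a sulfamoyl-linked group with a carbamoyl-linked group and stays within the scatter, so that exchange on its own shifts nothing. Within the data shown here, no measured step covers the entering (5-amino-1-carboxypentyl)carbamoyl group. With both known values close together, the expectation for compound 4 in this assay is a number of the same order and no step beyond the scatter. Compound 4 is estimated at 4 nm/s, range 1.5 nm/s to 12 nm/s.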

Compound 4, apparent permeability: 4 nm/s
Compound 4: the middle estimate sits on the measured number at the digits printed, within the range that was stated.
By their numbers in this assay, from the lowest: compounds 3, 4 and 2 (each within the scatter of the next).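

In this assay, the (5-amino-1-carboxypentyl)carbamoyl group gives no change at the digits printed from compound 3 to compound 4 (within the scatter) and a 1.3-fold lower number from compound 2 to compound 4 (0.10 log units; within the scatter). At this place, para to a large group, a chain carrying an amine alongside its carboxylic acid therefore stays within the scatter of both the 2-sulfoethyl and the sulfamoyl-linked chains. Nothing available accounts for this flat reading.

Steps involving compound 1 cannot be read. Still open, from the compounds shown here alone, is whether a carbamoyl chain ending in an amine alone, with no carboxylic acid or sulfonic acid, would move the number beyond the scatter.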